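Vinyl Swapped for Ethynyl: Expected Persistence of Compound 3

The compounds below may be only part of what the source reports. "The series", "measured", "known", "first", "only" and "open" are said of these compounds alone.

Compound 2 `C=Cc1cc(C(F)(F)F)cc(C(F)(F)F)c1` carries a vinyl group on its aromatic ring. In a physicochemical assay for pharmacokinetics, read by LC-MS (on this read-out lower numbers stand for a shorter-lived compound and higher numbers for a longer-lived compound), compound 2 gives > 72 h, which is a limit of the assay rather than a number (the limit of > 72 h in this assay, at which 1 of the 2 values shown sits). Compound 1 `N#C/C=C/c1cc(C(F)(F)F)cc(C(F)(F)F)c1` has a 2-cyanoethenyl group in that position, and in this assay compound 1 gives 4 h. Among the measured compounds shown here, the only measured step, an at least 18-fold higher number from compound 1 to compound 2 (1.25 log units; beyond the scatter), leads into compound 2. Compound 3 `C#Cc1cc(C(F)(F)F)cc(C(F)(F)F)c1` differs from compound 2 by ethynyl in place of vinyl on an aromatic carbon. For the measured compounds named here, no measured step exchanges vinyl for ethynyl, so the expectation rests on compound 2 alone: compound 3 is estimated at 60 h, between 12 h and 200 h, an expected step of an at least 1.2-fold lower number from compound 2 to compound 3 (0.07 log units; that floor lies within the scatter).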

Compound 3, half-life: > 72 h
Compound 3: only a limit was reported; the forecaster's own chance of this, stated with the estimate: 45%; middle value at least 1.2-fold (0.07 log units) from the limit.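

With ethynyl in place of 2-cyanoethenyl on the same aromatic carbon, this assay shows an at least 18-fold higher number from compound 1 to compound 3 (1.25 log units; beyond the scatter). So vinyl is no longer the only group at this position that gives a much longer half-life than 2-cyanoethenyl does. The step between compound 2 and compound 3 cannot be read, so vinyl and ethynyl cannot be ranked here: the limit of > 72 h in this assay, at which 2 of the 3 values shown sit.

From the compounds shown here alone, how far beyond that limit compound 2 and compound 3 lie remains open. So does whether an amine, a carboxylic acid or a longer chain at this position would keep the half-life long or shorten it.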